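This account rests on a few compounds, and the source may have more. Where it says the series, first, only, none or still open, it means among the compounds named here.

Measured so far in a functional assay on HT-29 cells (Homo sapiens) for antiproliferative activity, read by MTT assay, with a stated time of 72 h; on this read-out lower numbers stand for stronger inhibition and higher numbers for weaker inhibition:
- compound 1 `COc1cc(-c2nccn2CC(C)C)cc(OC)c1OC` gives > 100000 nM (a limit)
- compound 2 `COc1cc(OC)cc(-n2ccnc2-c2cc(OC)c(OC)c(OC)c2)c1` gives 74500 nM
- compound 3 `COc1cc(-c2nccn2-c2cccc([N+](=O)[O-])c2)cc(OC)c1OC` gives > 100000 nM (a limit)

Compound 1 stands on the limit of > 100000 nM in this assay, at which 2 of the 3 values shown sit, and so has a limit, not a number. Compound 4 `COc1cc(-c2nccn2-c2ccc(Br)cc2)cc(OC)c1OC` carries 4-bromophenyl in place of isobutyl on an aromatic nitrogen. Among the measured compounds shown here, no measured step covers this change. Compound 2, with one six-membered aromatic ring of carbon only on that nitrogen, gives 74500 nM and hints at a small gain in this assay. Compound 3 goes against that gain, with its limit of > 100000 nM on the same kind of ring. The expected step is small, toward stronger inhibition at best (an at least 1.2-fold lower number from compound 1 to compound 4 (0.09 log units; that floor lies within the scatter)), and a limit reading is quite possible. Compound 4 is estimated at 80000 nM (expected range 30000 nM to 200000 nM).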

Compound 4, half-maximal inhibitory concentration: 7700 nM
For compound 4 the middle estimate is 10-fold (1.02 log units) above the measured one, outside the stated range (below it).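

In this assay, 4-bromophenyl in place of isobutyl on an aromatic nitrogen brings an at least 12-fold lower number from compound 1 to compound 4 (1.11 log units; beyond the scatter). This step is only a floor, as compound 1 has a limit and not a number: the limit of > 100000 nM in this assay, at which 2 of the 4 values shown sit. A six-membered aromatic ring of carbon only on this nitrogen is not enough by itself: compound 3 gives > 100000 nM, which is a limit.

From the compounds shown here alone, the share of the bromine stays open. The compounds shown do not tell how plain phenyl or 4-methoxyphenyl on this nitrogen would read.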